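The source may hold more compounds than are shown below. What is called first, only, known or untested is meant among the compounds shown, and "the series" means these compounds.

Of the compounds shown here, three of a shared core have been tested in a functional assay on A549 cells (Homo sapiens), read by MTT assay, with a stated time of 72 h (a lower number here means a stronger inhibitor, a higher number a weaker inhibitor), and none gave a number. Compound 1 `CNc1ncnc2c1c(-c1ccoc1)cn2[C@@H]1O[C@H](CO)[C@@H](O)[C@H]1O` reached only the limit of the assay, > 20000 nM. Compound 2 `Cc1ncnc2c1c(-c1ccoc1)cn2[C@@H]1O[C@H](CO)[C@@H](O)[C@H]1O`, which carries methyl in place of methylamino on an aromatic carbon, likewise gave only the limit > 20000 nM. The step that the two limits leave unreadable from compound 1 to compound 2 therefore cannot be read. Compound 3 `CSc1ncnc2c1c(-c1cccs1)cn2[C@@H]1O[C@H](CO)[C@@H](O)[C@H]1O`, the starting point here, also stands at the limit > 20000 nM, so its position can only be said to sit at or beyond that edge, as do the two other values shown; the limit is reached by every measured compound, (the limit of > 20000 nM in this assay, at which 3 of the 3 values shown sit).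

Compound 4 `CSc1ncnc2c1c(-c1ccoc1)cn2[C@@H]1O[C@H](CO)[C@@H](O)[C@H]1O` is the untested partner of compound 3, changed by furan-3-yl in place of thiophen-2-yl on an aromatic carbon. Among the compounds with values here, no measured step bears on this exact change. Within the data shown here, the only guide is that compound 1 and compound 2 already carry furan-3-yl and gave only the limit, and compound 3 with thiophen-2-yl gave only the limit, so no step beyond the scatter is expected. Compound 4 is therefore expected to give about 20000 nM, most likely reported again as a limit, within 8000 nM to 100000 nM, the step of a number no higher from compound 3 to compound 4 (the limit leaves the size open) being expected to be essentially nil.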

Compound 4, half-maximal inhibitory concentration: 280 nM
Compound 4: the middle estimate sits 71-fold (1.85 log units) above what was measured; measured number outside the range, below it.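

In this assay, thiophen-2-yl and furan-3-yl are not interchangeable at this aromatic carbon when methylsulfanyl is present on the shared core: the change to furan-3-yl brings an at least 71-fold lower number from compound 3 to compound 4 (1.85 log units; beyond the scatter). Furan-3-yl alone is not enough, since with it kept in place, methylsulfanyl instead of methyl brings an at least 71-fold lower number from compound 2 to compound 4 (1.85 log units; beyond the scatter), and methylsulfanyl instead of methylamino brings an at least 71-fold lower number from compound 1 to compound 4 (1.85 log units; beyond the scatter). Among the compounds shown, a measurable number appears only where furan-3-yl and methylsulfanyl occur together, and these steps are minimum sizes because the other compounds stand at a limit: the limit of > 20000 nM in this assay, at which 3 of the 4 values shown sit.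

The step between compound 1 and compound 2 cannot be read. Also open, from the compounds shown here alone, is whether thiophen-3-yl or furan-2-yl could replace furan-3-yl, and whether methoxy or a longer chain such as ethylsulfanyl could replace methylsulfanyl.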